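The source may report more compounds than this note shows. Statements on the series, on what has been measured and on what is new or still open speak of the compounds shown alone.

Series notes, three compounds measured and one open.

The shared core is shown in compound 1 `Nc1cc(N)c2nc(-c3ccccc3)c(Oc3ccc(Cl)c(Cl)c3)nc2c1`. In a functional assay on Hs-578T cells (Homo sapiens) for inhibition, read by sulforhodamine B assay, with a stated time of 48 h (on this read-out higher numbers stand for weaker inhibition of growth and lower numbers for stronger inhibition of growth), compound 1 gives 10700 nM. Compound 2 `CCOC(=O)[C@H](CCC(=O)O)NC(=O)c1ccc(Sc2nc3cc(N)cc(N)c3nc2-c2ccccc2)cc1` gives 13800 nM in this assay, a number that sits within the scatter of compound 1. Compound 3 `COc1cc(CNc2nc3cc(N)cc(N)c3nc2-c2ccccc2)cc(OC)c1OC` gives 3020 nM, a number that lies beyond the scatter below compound 1. Among the three measured numbers, compound 1 is the second highest; its nearest neighbour is compound 2 and the furthest is compound 3.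

Compound 4 `Nc1cc(N)c2nc(-c3ccccc3)c(Sc3ccc(Cl)c(Cl)c3)nc2c1` is not yet measured. It differs from compound 1 in one place: (3,4-dichlorophenyl)sulfanyl in place of 3,4-dichlorophenoxy on an aromatic carbon. Going by the values given here, no pair of measured compounds isolates this change, since compound 2 carries a sulfanyl linker but with a different aryl group, so its value and that of compound 1 can only be read as two numbers that sit within the scatter of each other.

The step from compound 1 to compound 4 is expected to be small, a 1.3-fold lower number from compound 1 to compound 4 (0.10 log units; within the scatter), with no firm direction beyond the scatter. Compound 4 is therefore estimated at 8500 nM in this assay, within a range from 3000 nM to 25000 nM.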

Compound 4, concentration for 50% growth inhibition: 30200 nM
Compound 4: the middle estimate sits 3.6-fold (0.55 log units) below what was measured, and the stated range ends below it.
By their numbers in this assay, from the lowest: compound 3; then compounds 1 and 2 (each within the scatter of the next); then compound 4.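

In this assay, the atom linking the 3,4-dichlorophenyl ring to the shared core matters at this position, on an aromatic carbon next to the ring nitrogen and ortho to a phenyl group: (3,4-dichlorophenyl)sulfanyl in place of 3,4-dichlorophenoxy gives a 2.8-fold higher number from compound 1 to compound 4 (0.45 log units; beyond the scatter). Going by these compounds alone, this pair is the first to isolate the linking atom, with the aryl part kept and only oxygen exchanged for sulfur, and the step, though modest, lies beyond the scatter. Nothing available explains this difference.

The compounds shown leave open how a sulfonyl or a methylene linker carrying the same 3,4-dichlorophenyl ring would compare at this position. They also leave open whether the oxygen-to-sulfur step holds with an unsubstituted phenyl ring in place of 3,4-dichlorophenyl.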